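The source may hold more compounds than are shown below. What is called first, only, known or untested is meant among the compounds shown, and "the series" means these compounds.

Measured compounds and values:
- compound 1 `COc1ccc(C2C(C#N)=C(N)N(c3ccc(S(N)(=O)=O)cc3)C3=C2CCCC3)cc1`: 100%
- compound 2 `N#CC1=C(N)N(c2ccc(S(N)(=O)=O)cc2)C2=C(CCCC2)C1c1ccc(Cl)c(Cl)c1`: 50%

In a functional assay on Ehrlich cells (Mus musculus) for cytotoxicity, read by trypan blue exclusion, with a stated time of 2 h, tested at 100 ug/mL (on this read-out higher numbers stand for a stronger effect at the one concentration tested and lower numbers for a weaker effect), compound 1 gives 100% and compound 2 gives 50%. Among the compounds with values here, compound 2 stands lowest of the two numbers; its nearest neighbour is compound 1, and the one measured step is a number 50 percentage points lower from compound 1 to compound 2 (beyond the scatter), so exchanging the group on the saturated ring carbon has already moved the read-out by a large amount.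

Compound 3 `Cc1ccc(C2C(C#N)=C(N)N(c3ccc(S(N)(=O)=O)cc3)C3=C2CCCC3)o1` is the next member to be measured. It differs from compound 2 in the same place: 5-methylfuran-2-yl in place of 3,4-dichlorophenyl on a saturated ring carbon. Within the data shown here, no measured step covers a five-membered aromatic ring entering at this position, so the only guide is the step from compound 1 to compound 2, which shows that the read-out in this assay responds strongly to what sits on this carbon. The direction for a 5-methylfuran-2-yl group is not fixed by the two measured compounds.

Compound 3 is therefore expected to land between the two measured values, with a step of a number 20 percentage points higher from compound 2 to compound 3 (beyond the scatter) estimated from compound 2. For compound 3 the estimate is 70%, with a range from 35% to 100%, reflecting the wide spread that a single large step leaves open.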

Compound 3, a percentage reported as activity, at one concentration (the size of the read-out at that concentration, not a potency): 30%
Beside the measured number, compound 3's estimate is 40 percentage points above it; measured number below the stated range.
By their numbers in this assay, from the lowest: compound 3; then compound 2; then compound 1.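

Working notes on the group on the saturated ring carbon: in this assay the change to 5-methylfuran-2-yl lowers the read-out further (a number 20 percentage points lower from compound 2 to compound 3 (beyond the scatter)), so a five-membered aromatic ring with 1 hetero atom is tolerated here only with a loss, and the 3,4-dichlorophenyl group no longer marks the low end of the series. Against the 4-methoxyphenyl group the same change gives the widest gap seen so far (a number 70 percentage points lower from compound 1 to compound 3 (beyond the scatter)), which places both six-membered aromatic groups above the five-membered one, though with a single example of the latter, and this ordering holds for these three compounds only. No measurement on hand offers a cause for this order.

Since 5-methylfuran-2-yl differs from the other two groups in ring size, hetero atom and methyl group all at once, these three compounds cannot separate those features, and an unsubstituted furan-2-yl, a thiophen-2-yl or a plain phenyl group would be the direct comparisons. Also open, from the compounds shown here alone, is how an amine or a carboxylic acid on the aromatic ring at this carbon would read, and, with one concentration per compound, these figures give the size of the effect and say nothing about potency.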